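The compounds below may be only part of what the source reports. "The series", "measured", "known", "first", "only" and "open" are said of these compounds alone.

Compound 1 `Cn1cc(SCc2nnc(SCc3ccccc3)n2-c2c(Cl)cccc2Cl)c2ccccc21`: in a toxicity assay on HEK-293T cells (Homo sapiens) for cytotoxicity, read by CCK-8 assay, with a stated time of 48 h (a lower number here means that less compound is tolerated, a higher number that more compound is tolerated), compound 1 gives > 100000 nM, a limit of the assay.
Compound 2 `Cn1cc(SCc2nnc(SCc3ccccc3C#N)n2-c2c(Cl)cccc2Cl)c2ccccc21`: in this assay compound 2 gives 78600 nM.
Compound 3 `Cn1cc(SCc2nnc(SCc3cc(Cl)ccc3F)n2-c2c(Cl)cccc2Cl)c2ccccc21`: in this assay compound 3 gives > 100000 nM, again a limit.

Compound 3 thus stands at the limit of > 100000 nM in this assay, at which 2 of the 3 values shown sit, and its true value is not known beyond that. Compound 4 `Cn1cc(SCc2nnc(SCc3ccc(Cl)c(F)c3)n2-c2c(Cl)cccc2Cl)c2ccccc21` differs from it by 4-chloro-3-fluorophenyl in place of 5-chloro-2-fluorophenyl on a saturated chain carbon bound to a sulfur. Two measured steps reach compound 3: a step that the two limits leave unreadable from compound 1 to compound 3 and an at least 1.2-fold higher number from compound 2 to compound 3 (0.10 log units; that floor lies within the scatter). Among the compounds with values here, neither moves a halogen around the same ring, so no measured step speaks directly to the change; compound 3 sits at the limit, and the expectation is a step of a number no higher from compound 3 to compound 4 (the limit leaves the size open), none beyond the scatter. Compound 4 is therefore estimated at 100000 nM, between 50000 nM and 200000 nM, most likely again reported only as a limit.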

Compound 4, half-maximal cytotoxic concentration: > 100000 nM
Compound 4 was reported as a limit; the forecaster's own chance of this, stated with the estimate: 75%; the middle value sits exactly at the limit.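

With 4-chloro-3-fluorophenyl in place of 5-chloro-2-fluorophenyl on a saturated chain carbon bound to a sulfur, compound 4 also gives only a limit in this assay: the limit of > 100000 nM in this assay, at which 3 of the 4 values shown sit.

The steps to compound 4 from compound 1 and from compound 3 cannot be read, as both ends are limits. Within the data shown here, the one readable comparison is an at least 1.2-fold higher number from compound 2 to compound 4 (0.10 log units; that floor lies within the scatter).

From the compounds shown here alone, how far the true values of compound 1, compound 3 and compound 4 lie past the limit stays open. So does whether an amine or a carboxylic acid on this ring, or a longer chain to the sulfur, would give a readable number.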